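The compounds below may be only part of what the source reports. "The series", "measured", "known", "first", "only" and "open" are said of these compounds alone.

In a functional assay on SMMC-7721 cells (Homo sapiens) for antiproliferative activity, read by MTT assay, with a stated time of 48 h (on this read-out higher numbers stand for weaker inhibition and lower numbers for stronger inhibition), compound 3 (`Cn1cc(C2=C(c3nn(CCn4ccnc4)c4ncccc34)C(=O)NC2=O)c2ccccc21`) stands at a limit, > 100000 nM, and not at a number. Compound 1 (`Cn1cc(C2=C(c3nn(CCCn4ccnc4)c4ncccc34)C(=O)NC2=O)c2ccccc21`) also gives only a limit, > 100000 nM. Compound 2 (`Cn1cc(C2=C(c3nn(CCCCn4ccnc4)c4ncccc34)C(=O)NC2=O)c2ccccc21`) gives a number, 29200 nM. The series therefore sits largely at the limit of > 100000 nM in this assay, at which 2 of the 3 values shown sit.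

Compound 4 (`Cn1cc(C2=C(c3nn(CCCO)c4ncccc34)C(=O)NC2=O)c2ccccc21`) differs from compound 3 by hydroxymethyl in place of 1H-imidazol-1-yl on a saturated chain carbon, two bonds along the chain from an aromatic nitrogen. Cut one bond further out, 2-(1H-imidazol-1-yl)ethyl gives way to 3-hydroxypropyl.

Among the compounds with values here, no measured step makes this exchange. The nearest steps alter only the chain that carries the 1H-imidazol-1-yl group: there is an at least 3.4-fold lower number from compound 1 to compound 2 (0.53 log units; beyond the scatter), there is an at least 3.4-fold higher number from compound 2 to compound 3 (0.53 log units; beyond the scatter), and, with both ends at the limit, there is a step that the two limits leave unreadable from compound 1 to compound 3. At most a modest fall in the number is therefore expected in this assay, and a result at the limit remains quite possible. The expected change is an at least 1.6-fold lower number from compound 3 to compound 4 (0.22 log units; that floor lies within the scatter). The estimate for compound 4 is 60000 nM, with an expected range from 15000 nM to 150000 nM.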

Compound 4, half-maximal inhibitory concentration: > 100000 nM
Compound 4: no number, only a limit; the forecaster's own chance of this, stated with the estimate: 40%; middle value at least 1.6-fold (0.22 log units) away from the limit.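

In this assay compound 4 gives > 100000 nM, which is a limit and not a number, so hydroxymethyl in place of 1H-imidazol-1-yl at this place on the chain yields no measurable value. The steps to compound 4 from compound 1 and from compound 3 cannot be read, with a limit at both ends of each. Within the data shown here, the one readable step is an at least 3.4-fold higher number from compound 2 to compound 4 (0.53 log units; beyond the scatter), where hydroxy stands in place of (1H-imidazol-1-yl)methyl, three bonds along the chain from an aromatic nitrogen, and the only number in the set is lost.

On these data alone, whether hydroxymethyl or 1H-imidazol-1-yl gives the lower number at this place stays open, because the values rest largely at one limit: the limit of > 100000 nM in this assay, at which 3 of the 4 values shown sit. It also remains open whether an amine or a carboxylic acid on this chain, or a longer chain carrying 1H-imidazol-1-yl, would give a number lower than that of compound 2.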